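Oxytocin receptor ligands: a smaller amide at the carbonyl

This account rests on a few compounds, and the source may have more. Where it says the series, first, only, none or still open, it means among the compounds named here.

Of the compounds shown here, two sharing a common core have been measured in an assay on isolated protein for displacement of a labelled ligand from Oxytocin receptor (Homo sapiens); a higher number here means a weaker inhibitor, a lower number a stronger inhibitor. Compound 1 `CC[C@H](C)[C@@H]1C(=O)N[C@H](C2Cc3ccccc3C2)C(=O)N1[C@@H](C(=O)N(C)C)c1cc(C)cnc1C` gives 0.794 nM in this assay. Compound 2 `CCC(CC)[C@@H]1C(=O)N[C@H](C2Cc3ccccc3C2)C(=O)N1[C@@H](C(=O)N1CCOCC1)c1ccc(C)nc1C` gives 0.0316 nM in this assay, the lower of the two numbers, and its gap to compound 1 is well beyond the usual scatter. The two compounds differ in several places at once, so no single change can be read from that gap.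

Compound 3 `CCC(CC)[C@@H]1C(=O)N[C@H](C2Cc3ccccc3C2)C(=O)N1[C@@H](C(=O)NC)c1ccc(C)nc1C` has not yet been measured. It differs from compound 2 in one place: methylamino in place of morpholin-4-yl on a carbonyl carbon. Among the measured compounds shown here, nothing among the measured pairs shows this exact exchange in isolation, so the size of the step is uncertain. Compound 3 is expected to stay strong, with a modest rise in the inhibition constant estimated as a 3.2-fold higher number from compound 2 to compound 3 (0.50 log units; beyond the scatter). For compound 3 the value expected in this assay is 0.1 nM, between 0.02 nM and 0.5 nM.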

Compound 3, inhibition constant: 0.0501 nM
The estimate for compound 3 lay 2.0-fold (0.30 log units) above the measured number; the range from low to high includes it.
By their numbers in this assay, from the lowest: compounds 2 and 3 (each within the scatter of the next); then compound 1.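

Among the compounds shown here, the exchange of morpholin-4-yl for methylamino on a carbonyl carbon is the first single change that can be read in this assay, and it comes to a 1.6-fold higher number from compound 2 to compound 3 (0.20 log units; within the scatter). In this assay, compound 2 and compound 3 therefore cannot be told apart, although the entering group has no ring, far fewer heavy atoms and a hydrogen-bond donor that morpholin-4-yl lacks. No measurement among these data accounts for this result.

From the compounds shown here alone, whether ethylamino or piperidin-1-yl on the same carbonyl carbon, or a carboxylic acid in place of the amide, would also stay within the scatter of compound 2 remains open. The gap to compound 1 also remains unassigned, since it differs from compound 2 and compound 3 in more than one place.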